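From Phenyl to Benzyl on the Ring Nitrogen

The source may hold more compounds than are shown below. What is called first, only, known or untested is meant among the compounds shown, and "the series" means these compounds.

Of the compounds shown here, three sharing one core have been measured in an ADME assay on the whole organism (strain Sprague-Dawley) for pharmacokinetics, with Rattus norvegicus as the target, read by LC-MS, at a dose of 5 mg/kg by the intravenous route; a higher number here means more compound in the circulation at the dose given, a lower number less compound in the circulation. Compound 1 `C=CC(=O)N1CC[C@H](N2C(=O)N(c3ccccc3)Cc3cnc(Nc4ccc(N5CCN(C)CC5)cc4OC)nc32)C1` gives 3150 nM. Compound 2 `C=CC(=O)N1CC[C@H](N2C(=O)N(c3ccccc3)Cc3cnc(Nc4ccc(N5CCN(C)CC5)c(OC)c4)nc32)C1` gives 5990 nM, and compound 3 `C=CC(=O)N1CC[C@H](N2C(=O)N(c3ccccc3)Cc3cnc(Nc4ccc(N5CCN(C)CC5)c(C)c4)nc32)C1` gives 7190 nM. Compound 1 therefore stands lowest of the three: its gap to compound 2 lies within the scatter, while its gap to compound 3 lies beyond it. Going by the values given here, the only single-point step among the measured compounds, a 1.2-fold higher number from compound 2 to compound 3 (0.08 log units; within the scatter), concerns a group on an aromatic carbon and is within the scatter.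

Compound 4 `C=CC(=O)N1CC[C@H](N2C(=O)N(Cc3ccccc3)Cc3cnc(Nc4ccc(N5CCN(C)CC5)cc4OC)nc32)C1` differs from compound 1 in one place: benzyl in place of phenyl on an amide-type nitrogen in a ring. Among the compounds with values here, no measured step touches this position, so the measured series offers no direct guide for it, and the one step that is known was itself small. For this reason no step beyond the scatter is expected from compound 1 to compound 4 in this assay; the expected step is a 1.1-fold lower number from compound 1 to compound 4 (0.02 log units; within the scatter). Compound 4 is thus estimated at 3000 nM, with a range from 1400 nM to 6500 nM.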

Compound 4, maximal plasma concentration: 1350 nM
Compound 4: the middle estimate sits 2.2-fold (0.35 log units) above what was measured; measured number outside the range, below it.
By their numbers in this assay, from the lowest: compound 4; then compounds 1, 2 and 3 (each within the scatter of the next, the first and the last beyond it).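

The nitrogen in the ring of the shared core proves sensitive in this assay: benzyl in place of phenyl, a change of a single added carbon, gives a 2.3-fold lower number from compound 1 to compound 4 (0.37 log units; beyond the scatter), the only single change shown here that goes beyond the scatter. The earlier compounds shown here differ only elsewhere in the molecule, so they said nothing about this position, and the new group keeps the same aromatic ring and the same counts of hydrogen-bond donors and acceptors as the old one. Nothing available explains this step.

On these data alone, only compound 1 and compound 4 form this pair, so whether the step would hold with the other substituents on the core stays open. A longer chain such as phenethyl, or a small methyl, on this nitrogen would show how the number runs with the size of the group.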